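Methyl for chloro in a positive allosteric modulator series

This account rests on a few compounds, and the source may have more. Where it says the series, first, only, none or still open, it means among the compounds named here.

Of the compounds shown here, three have been measured in an assay on HEK293 cells for positive allosteric modulation of metabotropic glutamate receptor 3 (Rattus norvegicus), read by thallium flux, with a stated time of 2.5 min; on this read-out higher numbers stand for larger maximal responses and lower numbers for smaller maximal responses. Compound 1 `Cc1c(OCCCCOc2ccccc2C(=O)O)ccc(C(=O)CC2CCCC2)c1C` gives 28%, compound 2 `Cc1c(OCCCCOc2ccc(C(=O)O)cc2Cl)ccc(C(=O)CC2CCCC2)c1O` gives 27.4%, and compound 3 `COc1ccc(C(=O)O)cc1OCCCCOc1ccc(C(=O)C(C)C)c(O)c1C` gives 59.9%. Compound 2 thus sits at the low end of the three: its value and that of compound 1 lie within the scatter of each other, while compound 3 stands higher by a margin beyond the scatter. Compound 4 `Cc1cc(C(=O)O)ccc1OCCCCOc1ccc(C(=O)CC2CCCC2)c(O)c1C` is not yet measured in this assay. It differs from compound 2 by methyl in place of chloro on an aromatic carbon. Among the compounds with values here, no pair of measured compounds isolates this change, so the expected step of a number 5.6 percentage points higher from compound 2 to compound 4 (within the scatter) is small and of uncertain direction, likely not beyond the scatter. Compound 4 is expected to reach 33%, with a range from 15% to 55%.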

Compound 4, largest response reached (reported as percent of maximum), in percent of the reference or control that the assay uses: 28.4%
The estimate for compound 4 lay 4.6 percentage points above the measured number, within the range that was stated.
By their numbers in this assay, from the lowest: compounds 2, 1 and 4 (each within the scatter of the next); then compound 3.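

This pair isolates the change: in this assay, methyl in place of chloro on this aromatic carbon, ortho to a large group and meta to a carboxy group, gives a number 1 percentage points higher from compound 2 to compound 4 (within the scatter) on the otherwise shared structure. At this position, the read-out therefore does not separate the two groups. Nothing shown offers an explanation for this result.

From the compounds shown here alone, whether an amine or a fluoro group at this position would also leave the maximal response within the scatter remains open. Going by these compounds, it is also open whether the same exchange would behave alike on the core of compound 3.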